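Swapping the Aryl Group on the Ring Amine Nitrogen

The compounds below may be only part of what the source reports. "The series", "measured", "known", "first", "only" and "open" are said of these compounds alone.

Three compounds share one core and differ only in the aromatic group on an amine nitrogen in a ring. Compound 1 `Cc1ccc(N2CCN(Cn3nc(-c4ccc5c(c4)OCCO5)oc3=S)CC2)c(C)c1` carries a 2,4-dimethylphenyl group. In a functional assay on SW 1116 cells (Homo sapiens) for antiproliferative activity, read by MTT assay, with a stated time of 48 h (on this read-out higher numbers stand for weaker inhibition and lower numbers for stronger inhibition), compound 1 reaches only the assay limit of > 50000 nM. Compound 2 `S=c1oc(-c2ccc3c(c2)OCCO3)nn1CN1CCN(c2cccc(Cl)c2Cl)CC1` carries a 2,3-dichlorophenyl group, and in this assay compound 2 gives 37100 nM. Compound 3 `COc1ccc(N2CCN(Cn3nc(-c4ccc5c(c4)OCCO5)oc3=S)CC2)cc1`, with a 4-methoxyphenyl group, gives 24200 nM in this assay, the lowest of the two numbers, although a 1.5-fold lower number from compound 2 to compound 3 (0.19 log units; within the scatter) lies within the scatter. The change from compound 1 was larger, an at least 2.0-fold lower number from compound 1 to compound 3 (0.31 log units; beyond the scatter), and an at least 1.3-fold lower number from compound 1 to compound 2 (0.12 log units; that floor lies within the scatter) was smaller still.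

Compound 4 `S=c1oc(-c2ccc3c(c2)OCCO3)nn1CN1CCN(c2ccccn2)CC1` alters the same position: pyridin-2-yl in place of 4-methoxyphenyl on an amine nitrogen in a ring. Every measured step bearing on this change is a swap of the aryl group on this nitrogen, and none moved the number far. The expected step, a 1.2-fold higher number from compound 3 to compound 4 (0.09 log units; within the scatter), is therefore estimated to stay within the scatter. Compound 4 is expected near 30000 nM, with a range of 10000 nM to 60000 nM.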

Compound 4, half-maximal inhibitory concentration: 9490 nM
Compound 4: the middle estimate sits 3.2-fold (0.50 log units) above what was measured; measured number outside the range, below it.
By their numbers in this assay, from the lowest: compound 4; then compounds 3 and 2 (each within the scatter of the next). At a limit, above all of these: compound 1.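

In this assay, pyridin-2-yl stands apart from the carbon-only aryl groups: a 2.6-fold lower number from compound 3 to compound 4 (0.41 log units; beyond the scatter), and a 3.9-fold lower number from compound 2 to compound 4 (0.59 log units; beyond the scatter). Both steps lie beyond the scatter, whereas compounds 2 and 3 lie within the scatter of each other, so this position does respond to the choice of aromatic ring, and compound 4 is the most active of the four. The remaining step, an at least 5.2-fold lower number from compound 1 to compound 4 (0.72 log units; beyond the scatter), is only a floor, set by a limit of the assay: the limit of > 50000 nM in this assay, at which 1 of the 4 values shown sits.

With a single ring bearing a hetero atom, the compounds shown leave open whether the lower number follows from that ring nitrogen or from the absence of a substituent on the ring. Plain phenyl, pyridin-4-yl and pyrimidin-2-yl on this amine nitrogen would separate these readings.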